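The compounds below may be only part of what the source reports. "The series", "measured", "known", "first", "only" and "open" are said of these compounds alone.

Measured so far:
Compound 1 `CCN(CC)C(=O)Cn1c(-c2ccc(OC)cc2)cc2c(C)cc(C)cc21` gives 114 nM in an assay on membranes from HEK293 cells for displacement of a labelled ligand from Translocator protein (Homo sapiens), read by scintillation counting, with a stated time of 90 min; a higher number here means a weaker inhibitor, a lower number a stronger inhibitor.
Compound 2 `CCN(CC)C(=O)c1nc2ccccc2n1Cc1ccccc1` gives only a limit of this assay, > 10000 nM.
Compound 3 `CCN(CC)C(=O)c1nc2ccccc2n1Cc1ccc(Cl)cc1` likewise gives only a limit of this assay, > 10000 nM.

Within the data shown here, compound 3 therefore has no number of its own in this assay; it sits at the ceiling of what the assay reports, and it shares that position with compound 2, the one other compound built on the same core. Only compound 1, with a different core, yields a readable value. Among the measured compounds shown here, the one step that bears directly on compound 3 is a step that the two limits leave unreadable from compound 2 to compound 3, but because both ends rest at the limit of > 10000 nM in this assay, at which 2 of the 3 values shown sit, the size of that step cannot be read, so the change from a hydrogen to a chloro group on the aromatic ring teaches nothing measurable here.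

Compound 4 `CCN(CC)C(=O)c1nc2ccccc2n1Cc1ccc(OC)nc1` is reached from compound 3 by a single exchange: 6-methoxypyridin-3-yl in place of 4-chlorophenyl on a saturated chain carbon bound to an aromatic nitrogen. For the measured compounds named here, there is no measured step in this set that shows what such a swap does. Going by the values given here, the only guide is that every compound on the core of compound 3 has so far stayed at the limit. The expectation is that compound 4 behaves the same way, a step of about a number no higher from compound 3 to compound 4 (the limit leaves the size open), with an estimated value of 10000 nM and a likely range from 3000 nM to 30000 nM, most probably reported again only as a limit.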

Compound 4, inhibition constant: > 10000 nM
Compound 4 ended at the assay's limit; the forecaster's own chance of this, stated with the estimate: 70%; the middle value sits exactly at the limit.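

The steps from compound 2 and from compound 3 to compound 4 cannot be read, because all three compounds rest at one shared limit rather than at a number: the limit of > 10000 nM in this assay, at which 3 of the 4 values shown sit. The compounds shown leave open whether any group at this place on the shared core of compound 2, compound 3 and compound 4 would give a readable value.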